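The compounds below may be only part of what the source reports. "The series", "measured", "known", "first", "only" and "open" are said of these compounds alone.

Compound 1 `CC(=O)OC[C@H]1O[C@H](OC2=CC(=O)c3ccccc3C2=O)[C@H](OC(C)=O)[C@@H](OC(C)=O)[C@H]1OC(C)=O` and compound 2 `CC(=O)OC[C@H]1O[C@@H](OC2=CC(=O)c3ccccc3C2=O)[C@H](OC(C)=O)[C@@H](OC(C)=O)[C@H]1OC(C)=O` carry the same atoms and bonds and differ only in configuration as drawn. For the measured compounds named here, in a functional assay on MCF7 cells (Homo sapiens) for cytotoxicity, read by sulforhodamine B assay, with a stated time of 72 h (on this read-out higher numbers stand for weaker inhibition and lower numbers for stronger inhibition), compound 1 gives 4580 nM, and in this assay compound 2 gives 13600 nM, the highest of the two numbers so far, a step of a 3.0-fold higher number from compound 1 to compound 2 (0.47 log units; beyond the scatter) that can be traced only to the fact that compounds 1 and 2 differ only in the configuration as drawn. Compound 3 `CC(=O)OC[C@H]1O[C@@H](OC2=CC(=O)c3ccccc3C2=O)[C@H](OC(C)=O)[C@@H](OC(C)=O)[C@@H]1OC(C)=O` is not yet measured and differs from compound 2 by the two compounds have the same atoms and bonds and differ only in configuration as drawn: 1 of 5 stereo elements differ; a stereocentre at a saturated ring carbon is drawn S in compound 2 and R in compound 3. Going by the values given here, the only comparable step is that modest inversion, so a shift of similar size, in either direction, is expected in this assay. Compound 3 is estimated at 10000 nM, with a range from 3000 nM to 40000 nM. This estimate means an expected step of a 1.4-fold lower number from compound 2 to compound 3 (0.13 log units; within the scatter).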

Compound 3, half-maximal inhibitory concentration: 4760 nM
Estimate against measurement, compound 3: 2.1-fold (0.32 log units) above; the range from low to high includes it.
By their numbers in this assay, from the lowest: compounds 1 and 3 (each within the scatter of the next); then compound 2.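

In this assay, inverting a second stereocentre at a saturated ring carbon gives a 2.9-fold lower number from compound 2 to compound 3 (0.46 log units; beyond the scatter), so this centre also affects the number, and the change runs opposite to the earlier inversion. With both centres changed, the result is a 1.0-fold higher number from compound 1 to compound 3 (0.02 log units; within the scatter), so the two inversions together leave no difference that can be read beyond the scatter: the fact that compounds 1 and 3 differ only in the configuration as drawn

The compounds shown leave open whether the remaining stereocentres of the shared core affect the number in the same way. They also leave open whether these configurations would still matter if free hydroxyl groups or amines replaced the acetate esters.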